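Isopentyl in place of 3-methylphenyl on compound 1

The source may report more compounds than this note shows. Statements on the series, on what has been measured and on what is new or still open speak of the compounds shown alone.

In an ADME assay on liver for metabolic stability, with Liver microsome (Homo sapiens) as the target, read by LC-MS, using microsomes (a higher number here means faster removal of the compound, a lower number slower removal), compound 1 (`Cc1cccc([C@@H](O)C(=O)N2N=CC[C@H]2C(=O)NCc2cc(Cl)ccc2-n2cnnn2)c1`) gives < 12 mL.min-1.g-1 as a limit of the assay and not as a number. For compound 1 the data show the limit of < 12 mL.min-1.g-1 in this assay, at which 1 of the 3 values shown sits, and nothing more exact. Two other compounds give numbers. Compound 2 (`CC(C)(C)OC[C@@H](O)C(=O)N1[C@H](C(=O)NCc2cc(Cl)ccc2-n2cnnn2)C[C@@H]2C[C@@H]21`) gives 21 mL.min-1.g-1 in this assay and compound 3 (`COC(C)(C)[C@@H](O)C(=O)N1C[C@H]2C[C@H]2[C@H]1C(=O)NCc1cc(Cl)ccc1-n1cnnn1`) gives 23 mL.min-1.g-1 in this assay as well, two values that lie within the scatter of each other.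

Compound 4 (`CC(C)CC[C@@H](O)C(=O)N1N=CC[C@H]1C(=O)NCc1cc(Cl)ccc1-n1cnnn1`) keeps the core of compound 1 and takes isopentyl in place of 3-methylphenyl on a saturated chain carbon bound to a carbonyl carbon and an oxygen on a saturated carbon. Going by the values given here, no measured pair differs in one place only, so the size of this step cannot be read from a matched change. A modest move upward in this assay is expected, close to the edge of the scatter, with compound 3 at 23 mL.min-1.g-1 as the rough guide for where a measured number may land. The estimated step runs (an at least 1.8-fold higher number from compound 1 to compound 4 (0.26 log units; that floor lies within the scatter)) and remains uncertain in size, since compound 1 has only a limit. For compound 4 the expected value is 22 mL.min-1.g-1 with an estimated range from 12 mL.min-1.g-1 to 45 mL.min-1.g-1 in this assay once it is measured.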

Compound 4, intrinsic clearance in microsomes: 47 mL.min-1.g-1
Beside the measured number, compound 4's estimate is 2.1-fold (0.33 log units) below it; measured number above the stated range.
By their numbers in this assay, from the lowest: compounds 2 and 3 (each within the scatter of the next); then compound 4. At a limit, below all of these: compound 1.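

Going by these compounds alone, with the core of compound 1 held fixed, isopentyl in place of 3-methylphenyl on a saturated chain carbon bound to a carbonyl carbon and an oxygen on a saturated carbon gives, in this assay, an at least 3.9-fold higher number from compound 1 to compound 4 (0.59 log units; beyond the scatter) and so provides the first matched step in this set, showing that this position affects the read-out. Steps to compounds 2 and 3 cannot be read, since each differs from the others in more than one place, while this change replaces a six-membered aromatic ring of carbon only with a group that has no ring, and neither group carries hydrogen-bond donors, hydrogen-bond acceptors or a net charge. The step gives only a lower bound on the size of the change because compound 1 stands at a limit of the assay: the limit of < 12 mL.min-1.g-1 in this assay, at which 1 of the 4 values shown sits.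

The compounds shown leave open whether the higher number follows the loss of the aromatic ring or the presence of the open chain, a question that a cyclohexyl group at this place could help to separate. They also leave open how a shorter chain, such as propyl, or a pyridine ring would read in this assay on the same core.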